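The compounds below may be only part of what the source reports. "The series", "measured", "known", "first", "only" and "open" are said of these compounds alone.

Measured compounds:
Compound 1, `COC(=O)c1c(Nc2ccc(OC)cc2)sc(C(=O)c2ccc(OC)cc2)c1C`: 12%
Compound 2, `COC(=O)c1c(Nc2ccc(Cl)cc2)sc(C(=O)c2ccc(OC)cc2)c1C`: "not active" (no number reported)

In a functional assay, with a stated time of 150 min, tested at 20 ug/mL (a higher number here means a stronger effect of the compound at the concentration tested, a lower number a weaker effect), compound 1 gives 12%. For compound 2 the outcome in this assay is reported only as "not active" (no number reported), so no single number marks where compound 2 stands; it is recorded as showing no effect at the concentration tested. Compound 3, `COC(=O)c1c(Nc2ccc(Cl)cc2)sc(C(=O)c2ccc(C)cc2)c1C`, has not yet been measured. It differs from compound 2 in one place: methyl in place of methoxy on an aromatic carbon. Within the data shown here, no step between two measured compounds is available to show what such a change does here, so no shift beyond the scatter can be foreseen in either direction. Because compound 2 gave "not active" (no number reported), compound 3 is expected to stay low as well, quite possibly again without a clear effect. The activity of compound 3 in this assay is estimated at 5%, with a range from 0% to 15%.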

Compound 3, a percentage reported as activity, at one concentration (the size of the read-out at that concentration, not a potency): "not active" (no number reported)
Compound 3: no number reported; the estimate stays without a comparison.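

In this assay, among these compounds, compound 2 gives "not active" (no number reported) and compound 3 gives "not active" (no number reported) so no step between these two compounds can be read. The compounds shown leave open whether changing 4-methoxyphenyl to 4-methylphenyl can alter this activity at all, and no further measurement shown here bears on the result.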